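Removing tert-butoxycarbonyl from compound 2

The compounds below may be only part of what the source reports. "The series", "measured", "known", "first", "only" and "open" are said of these compounds alone.

Values in a functional assay on MDA-MB-231 cells (Homo sapiens) for inhibition, read by MTT assay, with a stated time of 72 h (a lower number here means a stronger inhibitor, a higher number a weaker inhibitor), so far, both of them limits and not numbers

Compound 1 `CC(C)[C@H](NC(=O)c1cc(Cl)ccc1OCCN)C(=O)Nc1ccc([N+](=O)[O-])cc1Cl` gives > 10000 nM
Compound 2 `CC(C)C[C@H](NC(=O)c1cc(Cl)ccc1OCCNC(=O)OC(C)(C)C)C(=O)Nc1ccc([N+](=O)[O-])cc1Cl` gives > 10000 nM

Compound 2 sits at the limit of > 10000 nM in this assay, at which 2 of the 2 values shown sit, and so offers no number to work from. Compound 3 `CC(C)C[C@H](NC(=O)c1cc(Cl)ccc1OCCN)C(=O)Nc1ccc([N+](=O)[O-])cc1Cl` has hydrogen in place of tert-butoxycarbonyl on an amine nitrogen and has yet to be measured. Among the measured compounds shown here, no measured pair shows this change, so any expectation rests on very little. Compound 1 also carries the 2-aminoethyl group, and its > 10000 nM is a limit. On that basis, no step beyond the scatter is expected in this assay, and any shift that does appear is expected toward stronger inhibition. The expected a number no higher from compound 2 to compound 3 (the limit leaves the size open) is therefore small. Compound 3 is estimated at 10000 nM, with an expected range from 3000 nM to 30000 nM, and another result reported only as a limit would be no surprise.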

Compound 3, half-maximal inhibitory concentration: > 10000 nM
Compound 3 ended at the assay's limit (the forecaster's own chance of this, stated with the estimate: 55%); the middle value sits exactly at the limit.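

In this assay compound 3 gives > 10000 nM as a limit and not a number. The steps to compound 3 from compound 2 and from compound 1 therefore cannot be read: the limit of > 10000 nM in this assay, at which 3 of the 3 values shown sit.

The compounds shown leave open whether removing tert-butoxycarbonyl or placing isobutyl for isopropyl changes inhibition at all, and what any member of this series would give as a measured number.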